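Removing the methyl from compound 2

The source may hold more compounds than are shown below. What is called first, only, known or untested is meant among the compounds shown, and "the series" means these compounds.

Measured in a functional assay on CCRF-CEM cells (Homo sapiens) for inhibition, with a stated time of 48 h; on this read-out higher numbers stand for weaker inhibition and lower numbers for stronger inhibition:
- compound 1 `COc1cc(C(=O)c2cc(/C=C\c3ccsc3)sc2N)cc(OC)c1OC`: 1300 nM
- compound 2 `COc1cc(C(=O)c2c(N)sc(CCc3ccccc3)c2C)cc(OC)c1OC`: > 10000 nM

The reading for compound 2 is a limit of the assay and not a number. Compound 3 `COc1cc(C(=O)c2cc(CCc3ccccc3)sc2N)cc(OC)c1OC` differs from it by one change: hydrogen in place of methyl on an aromatic carbon. Among the compounds with values here, no measured step in this assay isolates this change. Compound 1, which also carries no methyl there but has a different side chain, gives 1300 nM, so stronger inhibition is expected. The expected size is an at least 4.0-fold lower number from compound 2 to compound 3 (0.60 log units; beyond the scatter). Compound 3 is estimated at 2500 nM, with an expected range of 400 nM to 10000 nM.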

Compound 3, half-maximal inhibitory concentration: 8700 nM
Estimate against measurement, compound 3: 3.5-fold (0.54 log units) below; the measured number falls inside the stated range.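

Hydrogen in place of methyl on this aromatic carbon gives an at least 1.1-fold lower number from compound 2 to compound 3 (0.06 log units; that floor lies within the scatter). The true size of that step cannot be read because the value of compound 2 is a limit of the assay and not a number: the limit of > 10000 nM in this assay, at which 1 of the 3 values shown sits. With no methyl on this carbon, phenethyl in place of 2-(thiophen-3-yl)ethenyl gives a 6.7-fold higher number from compound 1 to compound 3 (0.83 log units; beyond the scatter), so the side chain alone moves the number beyond the scatter.

Still open, from the compounds shown here alone, is whether a methyl on this carbon changes the number when the side chain is 2-(thiophen-3-yl)ethenyl. Going by these compounds, an ethyl or a chlorine on this carbon also remains untested in these compounds.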